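Swapping fluoro for chloro on the pendant phenyl ring

This account rests on a few compounds, and the source may have more. Where it says the series, first, only, none or still open, it means among the compounds named here.

Compounds measured so far, with their values in a functional assay on A549 cells (Homo sapiens) for cytotoxicity, read by MTT assay, with a stated time of 72 h; a lower number here means a stronger inhibitor, a higher number a weaker inhibitor:
Compound 1 `O=C(Nc1nc2ccc(F)cc2s1)c1cn(-c2ccccc2)nc1-c1ccccc1` gives 10200 nM.
Compound 2 `O=C(Nc1nc2ccc(F)cc2s1)c1cn(-c2ccccc2)nc1-c1ccc(F)cc1` gives 6650 nM.
Compound 3 `COc1ccc2nc(NC(=O)c3cn(-c4ccccc4)nc3-c3ccc(F)cc3)sc2c1` gives > 50000 nM, which is a limit of the assay and not a number.

Among the two numbers, compound 2 stands lowest, but the step of a 1.5-fold lower number from compound 1 to compound 2 (0.19 log units; within the scatter) lies within the scatter, so compound 1 and compound 2 cannot be told apart on these data. Compound 3 only reached the limit (the limit of > 50000 nM in this assay, at which 1 of the 3 values shown sits), and the step of an at least 7.5-fold higher number from compound 2 to compound 3 (0.87 log units; beyond the scatter) is beyond the scatter.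

Compound 4 `O=C(Nc1nc2ccc(F)cc2s1)c1cn(-c2ccccc2)nc1-c1ccc(Cl)cc1` has not been measured. It differs from compound 2 by chloro in place of fluoro on an aromatic carbon. Going by the values given here, two measured steps bear on it. The step of a 1.5-fold lower number from compound 1 to compound 2 (0.19 log units; within the scatter) altered the same aromatic carbon, putting fluoro in place of hydrogen, and stayed within the scatter. The step of an at least 7.5-fold higher number from compound 2 to compound 3 (0.87 log units; beyond the scatter) was larger, but it altered a different part of the molecule, the shared core, not the phenyl ring changed here. A halogen swap at a position that tolerated fluoro without a notable shift is therefore expected to give no step beyond the scatter in this assay, estimated as a 1.2-fold lower number from compound 2 to compound 4 (0.08 log units; within the scatter). Compound 4 is estimated at 5500 nM, with a range from 2000 nM to 16000 nM.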

Compound 4, half-maximal inhibitory concentration: 8860 nM
Compound 4: the middle estimate sits 1.6-fold (0.21 log units) below what was measured, and the stated range covers the measured number.
By their numbers in this assay, from the lowest: compounds 2, 4 and 1 (each within the scatter of the next). At a limit, above all of these: compound 3.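

In this assay, chloro in place of fluoro gives a 1.3-fold higher number from compound 2 to compound 4 (0.12 log units; within the scatter), and chloro in place of hydrogen gives a 1.2-fold lower number from compound 1 to compound 4 (0.06 log units; within the scatter). The earlier compounds had shown only that fluoro on this aromatic carbon, para to a large group, could not be told apart from hydrogen; compound 4 extends this to a second, larger halogen atom, so compound 1, compound 2 and compound 4 form one group within the scatter, and this position shows no preference among hydrogen, fluoro and chloro in this cytotoxicity read-out. No measurement shown bears on what lies behind this sameness.

Going by these compounds, what stays open is whether this position is equally indifferent to groups of a different kind, such as an amine or a carboxylic acid, or to something bulkier such as a longer chain, any of which might move the number beyond the scatter. On these data alone, it is also open whether the 4-chlorophenyl group would behave as the 4-fluorophenyl group does when the substituent on the shared core is altered.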